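Bromo to Methoxy: an Expected Value for Compound 3

A few compounds are considered here, and "the series" means these few. Any claim that something is new, unique, unknown or untested is made for them only; others in the source may bear on it.

Measured so far:
- compound 1, `COC(=O)[C@@]1(C)CC[C@@H]2C3=C1CC[C@@H](C)[C@]3(C)Cc1c2[nH]c2ccc(C)cc12`: 11000 nM
- compound 2, `COC(=O)[C@@]1(C)CC[C@@H]2C3=C1CC[C@@H](C)[C@]3(C)Cc1c2[nH]c2ccc(Br)cc12`: 16000 nM

Both were tested in a functional assay on HBL-100 cells (Homo sapiens) for inhibition, read by sulforhodamine B assay, with a stated time of 48 h; on this read-out lower numbers stand for stronger inhibition of growth and higher numbers for weaker inhibition of growth. Among the compounds with values here, compound 2 stands at the highest of the two numbers, but its only neighbour is compound 1, and the step of a 1.5-fold higher number from compound 1 to compound 2 (0.16 log units; within the scatter) is within the scatter, so the two cannot be told apart on this read-out.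

Compound 3, `COC(=O)[C@@]1(C)CC[C@@H]2C3=C1CC[C@@H](C)[C@]3(C)Cc1c2[nH]c2ccc(OC)cc12`, is the next variation. It differs from compound 2 in one place: methoxy in place of bromo on an aromatic carbon. Within the data shown here, the only step that bears on it is the exchange of methyl for bromo at the same position, a 1.5-fold higher number from compound 1 to compound 2 (0.16 log units; within the scatter), which changed nothing beyond the scatter. On that basis, a further exchange at this position is expected to leave the number essentially where it is, with no direction beyond the scatter; the expected step is a 1.2-fold lower number from compound 2 to compound 3 (0.09 log units; within the scatter). The estimate for compound 3 in this assay is 13000 nM, with a range from 6000 nM to 30000 nM.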

Compound 3, concentration for 50% growth inhibition: 5000 nM
For compound 3 the middle estimate is 2.6-fold (0.41 log units) above the measured one; measured number below the stated range.
By their numbers in this assay, from the lowest: compound 3; then compounds 1 and 2 (each within the scatter of the next).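

In this assay this position proves able to respond to the group it carries: there is a 3.2-fold lower number from compound 2 to compound 3 (0.51 log units; beyond the scatter), and there is also a 2.2-fold lower number from compound 1 to compound 3 (0.34 log units; beyond the scatter), whereas the exchange of methyl for bromo had stayed within the scatter. Methoxy, with two heavy atoms and one hydrogen-bond acceptor where bromo has one heavy atom and no acceptor, thus sets compound 3 apart from compounds 1 and 2, which cannot be told apart from each other. No measurement shown here explains why methoxy stands apart from the other two groups.

The compounds shown leave open whether an ethoxy group, a hydroxyl group or an amine at this position would lower the number further or return it to the level of compounds 1 and 2. They also leave open whether methoxy would have the same effect if a carboxylic acid replaced the methyl ester on the shared core.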